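The source may report more compounds than this note shows. Statements on the series, on what has been measured and on what is new or still open speak of the compounds shown alone.

Compound 3 `Cc1ccnc(NS(=O)(=O)c2ccc3nc(-c4ccccc4)c(-c4ccccc4)nc3c2)c1` is the starting point of this step. In an ADME assay on the whole organism for pharmacokinetics, with Homo sapiens as the target (a lower number here means that a smaller share of the oral dose reaches the circulation, a higher number that a larger share of the oral dose reaches the circulation), compound 3 gives 100%, level with compound 2 `O=S(=O)(Nc1cccc2ccccc12)c1ccc2nc(-c3ccccc3)c(-c3ccccc3)nc2c1`, for which this assay gives 100%; the step of no change at the digits printed from compound 2 to compound 3 (within the scatter) shows no movement. Compound 1 `O=S(=O)(Nc1ccc(O)cc1)c1ccc2nc(-c3ccccc3)c(-c3ccccc3)nc2c1`, the third member of the series, gives 93.9% in this assay, and the step of a number 6.1 percentage points higher from compound 1 to compound 3 (within the scatter) stays within the scatter, as does a number 6.1 percentage points higher from compound 1 to compound 2 (within the scatter). Compound 4 `O=S(=O)(Nc1ccccc1)c1ccc2nc(-c3ccccc3)c(-c3ccccc3)nc2c1` carries a different group on the sulfonamide nitrogen: phenyl in place of 4-methylpyridin-2-yl on a sulfonamide nitrogen. The three measured steps all alter the same position, and none of them moves the read-out beyond the scatter, so the exchange of one aromatic ring for another at this nitrogen has so far left this assay essentially unchanged. The step to compound 4 is therefore expected to be a number 3 percentage points lower from compound 3 to compound 4 (within the scatter), with no movement beyond the scatter. Compound 4 is estimated to give 97% in this assay, within a range of 85% to 100%.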

Compound 4, oral bioavailability: 100%
Compound 4: middle estimate off by 3 percentage points, on the low side; the range from low to high includes it.
By their numbers in this assay, from the lowest: compounds 1, 2, 3 and 4 (each within the scatter of the next).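

Compound 4 shows that in this assay phenyl, a ring of carbon only with no hydrogen-bond acceptor, cannot be told apart on the sulfonamide nitrogen from 4-methylpyridin-2-yl (no change at the digits printed from compound 3 to compound 4 (within the scatter)) or naphthalen-1-yl (no change at the digits printed from compound 2 to compound 4 (within the scatter)). Going by these compounds alone, it also gives the first step confined to a single substituent on this ring, hydrogen in place of hydroxy on an aromatic carbon (a number 6.1 percentage points higher from compound 1 to compound 4 (within the scatter)), so neither the ring nitrogen and methyl of compound 3 nor the hydroxy of compound 1 is needed for a result within the scatter of the others. No evidence is available that bears on this result.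

All four groups on this nitrogen are aromatic rings. The compounds shown leave open how the read-out responds to a saturated ring such as cyclohexyl, a chain such as ethyl, or a phenyl ring carrying a carboxylic acid or an amine.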